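Sulfonyl group exchange in a series at the assay limit

A few compounds are considered here, and "the series" means these few. Any claim that something is new, unique, unknown or untested is made for them only; others in the source may bear on it.

Measured in an ADME assay on HEK293 cells (Homo sapiens) for cytotoxicity, with a stated time of 72 h; on this read-out higher numbers stand for an effect only at larger amounts of compound and lower numbers for an effect already at smaller amounts:
- compound 1 `C=C[C@@](C)(/C=C/c1ccc(OCc2ccccc2)cc1)CCC=C(C)C`: > 36600 nM (a limit)
- compound 2 `C=C[C@@](C)(/C=C/c1ccc(OS(=O)(=O)C(F)(F)F)cc1)CCC=C(C)C`: > 36600 nM (a limit)

Compound 2 is known only through a limit, > 36600 nM. The evidence so far is the limit of > 36600 nM in this assay, at which 2 of the 2 values shown sit. Compound 3 `C=C[C@@](C)(/C=C/c1ccc(OS(=O)(=O)c2ccc(C)cc2)cc1)CCC=C(C)C` carries 4-methylphenyl in place of trifluoromethyl on a sulfonyl sulfur. Among the measured compounds shown here, with the one measured step being a step that the two limits leave unreadable from compound 1 to compound 2, no size can be carried over, so no step beyond the scatter is expected in this assay, and another limit is the likely report. Should a number appear, compound 3 is expected at 40000 nM, with an estimated range of 15000 nM to 80000 nM. This estimate corresponds to an expected step that the limit leaves unreadable from compound 2 to compound 3.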

Compound 3, half-maximal effective concentration: > 36600 nM
Compound 3 ended at the assay's limit (the forecaster's own chance of this, stated with the estimate: 80%); the middle value does not contradict the limit.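

In this assay compound 3 gives > 36600 nM, a limit and not a number. Among the compounds shown here, no step can therefore be read from compound 2 to compound 3. The compounds shown leave open whether compound 1, compound 2 and compound 3 differ at all on this read-out.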